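From 2-phenylethenyl to thiophen-3-yl on the shared core

The compounds below may be only part of what the source reports. "The series", "measured", "known", "first", "only" and "open" are said of these compounds alone.

For the measured compounds named here, in a functional assay on CAPAN-1 cells (Homo sapiens) for antiproliferative activity, with a stated time of 72 h (a lower number here means a stronger inhibitor, a higher number a weaker inhibitor), compound 2 `Nc1ncnn2c([C@@H]3O[C@H](CO)[C@@H](O)[C@H]3O)cc(/C=C/c3ccccc3)c12` gives 2600 nM and holds the lower of the two numbers so far, while compound 1 `Nc1ncnn2c([C@@H]3O[C@H](CO)[C@@H](O)[C@H]3O)cc(-c3ccc(F)cc3F)c12` gives 50900 nM on the same core. Compound 3 `Nc1ncnn2c([C@@H]3O[C@H](CO)[C@@H](O)[C@H]3O)cc(-c3ccsc3)c12` carries thiophen-3-yl in place of 2-phenylethenyl on an aromatic carbon and so loses the double bond outside aromatic rings, as compound 1 lacks it. Going by the values given here, the only measured step bearing on this is large, a 20-fold lower number from compound 1 to compound 2 (1.29 log units; beyond the scatter) with 2-phenylethenyl entering, though one step is thin support. The expected change in this assay is a 4.6-fold higher number from compound 2 to compound 3 (0.66 log units; beyond the scatter) by this estimate. Compound 3 is therefore estimated at 12000 nM with a range of 2500 nM to 50000 nM expected.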

Compound 3, half-maximal inhibitory concentration: 56200 nM
Compound 3: middle estimate off by 4.7-fold (0.67 log units), on the low side; the measured number lies above the stated range.
By their numbers in this assay, from the lowest: compound 2; then compounds 1 and 3 (each within the scatter of the next).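

In this assay the change to thiophen-3-yl gives a 22-fold higher number from compound 2 to compound 3 (1.33 log units; beyond the scatter) and so removes the advantage held by 2-phenylethenyl at this position. Thiophen-3-yl and 2,4-difluorophenyl show a 1.1-fold higher number from compound 1 to compound 3 (0.04 log units; within the scatter) and cannot be told apart, leaving 2-phenylethenyl, the only one of the three groups with a double bond outside aromatic rings, alone at the lower number. Nothing available explains this difference. On these data alone, whether the double bond or the distant phenyl ring matters remains open. A saturated 2-phenylethyl chain or a phenylethynyl group at this position could separate the two.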